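A few compounds are considered here, and "the series" means these few. Any claim that something is new, unique, unknown or untested is made for them only; others in the source may bear on it.

Measured compounds:
compound 1 `OC(CCn1nc2c(Br)c(Br)c(Br)c(Br)c2n1)c1cccc(Br)c1` gives 52%
compound 2 `COc1cccc(C(O)CCn2nc3c(Br)c(Br)c(Br)c(Br)c3n2)c1` gives 71%
compound 3 `C[C@@H](O)CCn1nc2c(Br)c(Br)c(Br)c(Br)c2n1` gives 105%

In a functional assay on MCF7 cells (Homo sapiens) for antiproliferative activity, read by MTT assay, with a stated time of 24 h, tested at 25 uM (on this read-out higher numbers stand for a weaker effect at the one concentration tested and lower numbers for a stronger effect), compound 2 stands second highest of the three numbers, with compound 1 below it and compound 3 above it, both beyond the scatter. Compound 4 `OC(CCn1nc2c(Br)c(Br)c(Br)c(Br)c2n1)c1ccccc1` differs from compound 2 by hydrogen in place of methoxy on an aromatic carbon. Going by the values given here, the one measured step that touches this ring is a number 19 percentage points higher from compound 1 to compound 2 (beyond the scatter), a modest rise. Among the compounds with values here, no measured pair shows hydrogen against methoxy, so the account rests on that single step and the size of the change cannot be read from it directly. The step expected in this assay is a number 5 percentage points lower from compound 2 to compound 4 (within the scatter), small and within the scatter. Compound 4 is therefore estimated at 66%, with a range from 48% to 88%.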

Compound 4, a percentage reported as activity, at one concentration (the size of the read-out at that concentration, not a potency): 99%
Beside the measured number, compound 4's estimate is 33 percentage points below it; the whole stated range lies below it.
By their numbers in this assay, from the lowest: compound 1; then compound 2; then compounds 4 and 3 (each within the scatter of the next).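

In this assay, hydrogen on this aromatic carbon gives a weaker effect than either substituent: the methoxy comparison shows a number 28 percentage points higher from compound 2 to compound 4 (beyond the scatter), and the bromo comparison shows a number 47 percentage points higher from compound 1 to compound 4 (beyond the scatter), a larger step. The earlier compounds shown here compared only two substituents; compound 4 shows that both go with a stronger effect than the unsubstituted phenyl. No measured evidence explains this difference.

As far as these compounds go, whether an amine, a nitrile or a carboxylic acid on this carbon would also lower the number remains open. So does whether methoxy or bromo would do so on another carbon of the ring.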